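Notes on the spiro series: compound 3 to compound 4

The source may hold more compounds than are shown below. What is called first, only, known or untested is meant among the compounds shown, and "the series" means these compounds.

Compound 3 `N#CC1=C(N)Oc2c(N)cc3nc4ccccc4nc3c2C12C(=O)N(Cc1cnnn1-c1ccccc1Cl)c1ccccc12` stands only at a limit in a functional assay on HCT-116 cells (Homo sapiens) for antiproliferative activity, read by MTT assay, with a stated time of 48 h; a higher number here means a weaker inhibitor, a lower number a stronger inhibitor: compound 3 gives > 50000 nM, a limit of the assay rather than a number. Compound 1 `N#CC1=C(N)Oc2c(c3nc4ccccc4nc3c3ccccc23)C12C(=O)N(Cc1cnnn1-c1ccccc1Br)c1ccccc12` gives > 50000 nM, likewise a limit. Compound 2 `N#CC1=C(N)Oc2c(c3nc4ccccc4nc3c3ccccc23)C12C(=O)N(Cc1cnnn1-c1cc(Cl)ccc1Cl)c1ccccc12` gives > 50000 nM, also a limit. Going by the values given here, the one step among the measured compounds, a step that the two limits leave unreadable from compound 1 to compound 2, is therefore unreadable. All three sit at the limit of > 50000 nM in this assay, at which 3 of the 3 values shown sit. Compound 4 `CCc1cccc(C)c1-n1nncc1CN1C(=O)C2(C(C#N)=C(N)Oc3c(N)cc4nc5ccccc5nc4c32)c2ccccc21` differs from compound 3 by 2-ethyl-6-methylphenyl in place of 2-chlorophenyl on an aromatic nitrogen. No measured step bears on this change, so no direction beyond the scatter can be argued from the numbers shown. Compound 4 is expected to sit at the limit as well, with the expected step of a number no higher from compound 3 to compound 4 (the limit leaves the size open) amounting to nothing readable. The estimate for compound 4 is 50000 nM, with range 20000 nM to 100000 nM.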

Compound 4, half-maximal inhibitory concentration: > 50000 nM
Compound 4 gave a limit, no number (the forecaster's own chance of this, stated with the estimate: 85%); the middle value lies on the limit itself.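

The step between compound 3 and compound 4 cannot be read, as both values are limits of the assay and not numbers. The compounds shown leave open whether any group on the aromatic nitrogen gives a readable value: the limit of > 50000 nM in this assay, at which 4 of the 4 values shown sit.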